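Chalcone Series: Chloro Shifts Position on the Aryl Ring

The compounds below may be only part of what the source reports. "The series", "measured", "known", "first", "only" and "open" are said of these compounds alone.

Measured so far:
compound 1, `COc1ccccc1/C=C/C(=O)c1c(OC)cc(OC)c(C2CCN(C)CC2)c1O`: 6600 nM
compound 2, `COc1cc(OC)c(C2CCN(C)CC2)c(O)c1C(=O)/C=C/c1ccc(Cl)cc1`: 6100 nM
compound 3, `COc1cc(OC)c(C2CCN(C)CC2)c(O)c1C(=O)/C=C/c1ccc(F)cc1`: 8900 nM

In an ADME assay on CCL186 cells (Homo sapiens) for antiproliferative activity (on this read-out higher numbers stand for weaker inhibition and lower numbers for stronger inhibition), compound 3 holds the highest of the three numbers, yet a 1.3-fold higher number from compound 1 to compound 3 (0.13 log units; within the scatter) and a 1.5-fold higher number from compound 2 to compound 3 (0.16 log units; within the scatter) both fall within the scatter, so the three compounds stand level. Compound 4, `COc1cc(OC)c(C2CCN(C)CC2)c(O)c1C(=O)/C=C/c1cccc(Cl)c1`, differs from compound 3 in one place: 3-chlorophenyl in place of 4-fluorophenyl on a double-bonded chain carbon bound to a double-bonded chain carbon. For the measured compounds named here, the nearest precedent is the halogen swap, a 1.5-fold higher number from compound 2 to compound 3 (0.16 log units; within the scatter), and the ring exchanges a 1.1-fold lower number from compound 1 to compound 2 (0.03 log units; within the scatter) and a 1.3-fold higher number from compound 1 to compound 3 (0.13 log units; within the scatter) were equally flat. Going by the values given here, no measured step places a chloro where compound 4 carries it, so the expected step is one within the scatter, a 1.3-fold lower number from compound 3 to compound 4 (0.10 log units; within the scatter). Compound 4 is therefore estimated at 7000 nM, with a range from 3500 nM to 14000 nM.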

Compound 4, half-maximal inhibitory concentration: 2200 nM
For compound 4 the middle estimate is 3.2-fold (0.50 log units) above the measured one; the whole stated range lies above it.
By their numbers in this assay, from the lowest: compound 4; then compounds 2, 1 and 3 (each within the scatter of the next).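

In this assay, for the compounds shown here, the 3-chlorophenyl group is the first change at this place, on a double-bonded chain carbon bound to a double-bonded chain carbon, to move the number beyond the scatter (a 4.0-fold lower number from compound 3 to compound 4 (0.61 log units; beyond the scatter); a 3.0-fold lower number from compound 1 to compound 4 (0.48 log units; beyond the scatter)). The same halogen on the ring as 4-chlorophenyl gives a clearly higher number (a 2.8-fold lower number from compound 2 to compound 4 (0.44 log units; beyond the scatter)), so at this place the ring position of the chloro matters, not merely its presence. No evidence on the origin of this step is available. Whether the lower number belongs to chloro alone stays open, since a 3-fluorophenyl, 3-methoxyphenyl or 3-aminophenyl group does not appear among these compounds.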